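Fluoro for Bromo on a Phenyl Tetrahydropyridine Core

The source may report more compounds than this note shows. Statements on the series, on what has been measured and on what is new or still open speak of the compounds shown alone.

Measured so far:
Compound 1, `OCc1cc(F)cc(C2=NCCCC2)c1`: 744 nM
Compound 2, `Brc1cccc(C2=NCCCC2)c1`: 5020 nM

Of the compounds shown here, two have been measured in an assay on cell membranes for displacement of a labelled ligand from Neuronal acetylcholine receptor; alpha4/beta2 (Rattus norvegicus), read by radioligand binding, with a stated time of 30 min; a higher number here means a weaker inhibitor, a lower number a stronger inhibitor. Compound 1 `OCc1cc(F)cc(C2=NCCCC2)c1` gives 744 nM in this assay, and compound 2 `Brc1cccc(C2=NCCCC2)c1` gives 5020 nM. Compound 2 therefore stands with the highest of the two numbers; its nearest neighbour, compound 1, gives a number lower by a gap that lies beyond the usual scatter. For the measured compounds named here, the two compounds differ in more than one place, so no single step links them, and their values show only that the pair spans a clear gap.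

Compound 3 `Fc1cccc(C2=NCCCC2)c1` has not yet been measured in this assay. It differs from compound 2 in a single place: fluoro in place of bromo on an aromatic carbon. Going by the values given here, no pair among the measured compounds shows what this exchange does on the shared core, so the expectation rests on the value of compound 2 alone. The step of a 1.3-fold lower number from compound 2 to compound 3 (0.10 log units; within the scatter) is expected to be small, either way, and not beyond the scatter. Compound 3 is accordingly estimated at 4000 nM, with a range from 1000 nM to 15000 nM.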

Compound 3, inhibition constant: 2040 nM
Compound 3: middle estimate off by 2.0-fold (0.29 log units), on the high side; measured number inside the range.
By their numbers in this assay, from the lowest: compound 1; then compound 3; then compound 2.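

In this assay, for the compounds shown here, fluoro in place of bromo on an aromatic carbon, meta to a group of 6 heavy atoms, gives a 2.5-fold lower number from compound 2 to compound 3 (0.39 log units; beyond the scatter) and so provides the first single-place comparison on the shared core: the number at this position responds to which of these two atoms is present, and the response, though modest, lies beyond the scatter. Compound 3 also links to compound 1 through a second single change, hydrogen in place of hydroxymethyl on an aromatic carbon, which gives a 2.7-fold higher number from compound 1 to compound 3 (0.44 log units; beyond the scatter) and shows that compound 1 keeps the lower number with hydroxymethyl present. The wide gap between compounds 1 and 2, which differ in more than one place, is thus divided into two modest steps, but nothing in the data explains either one.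

On these data alone, it remains open whether hydrogen, chloro, methoxy or an amine in place of fluoro would continue this trend on the shared core. As far as these compounds go, it also remains open whether hydroxymethyl would bring the same change alongside bromo, and whether a longer chain such as hydroxyethyl or a carboxylic acid in its place would do so alongside fluoro.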